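The source may hold more compounds than are shown below. What is called first, only, known or untested is meant among the compounds shown, and "the series" means these compounds.

In an ADME assay on MT4 cells (Homo sapiens) for cytotoxicity (on this read-out lower numbers stand for higher toxicity in this test and higher numbers for lower toxicity in this test), compound 1 (`O=C(NC(=S)Nc1cccc(C(F)(F)F)c1)c1ccccc1`) gives > 100000 nM, which is a limit of the assay and not a number. Within the data shown here, compound 2 (`CC[C@H]1CC[C@H](c2ccc(NC(=S)Nc3cccc(C(F)(F)F)c3)cc2)CC1`) gives 39000 nM, the only true number so far. Compound 3 (`CCOC(=O)c1ccc(NC(=S)Nc2cccc(C(F)(F)F)c2)cc1`) has not yet been measured. It differs from compound 2 by ethoxycarbonyl in place of 4-ethylcyclohexyl on an aromatic carbon, para to a large group: ethoxycarbonyl in place of 4-ethylcyclohexyl on an aromatic carbon. Among the measured compounds shown here, no measured step covers this change, so only a modest rise in this assay is expected, towards lower toxicity in this test and perhaps not far beyond the scatter. This expectation rests on compound 2, whose 39000 nM leaves little room before the top of the assay range. The estimated step is a 1.4-fold higher number from compound 2 to compound 3 (0.15 log units; within the scatter). For compound 3 the expected value is 55000 nM, with an estimated range of 15000 nM to 100000 nM.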

Compound 3, half-maximal cytotoxic concentration: 23000 nM
Beside the measured number, compound 3's estimate is 2.4-fold (0.38 log units) above it; low and high end bracket the measured number.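

Among these compounds, for the first time, a change on this aromatic carbon can be read in this assay: ethoxycarbonyl in place of 4-ethylcyclohexyl gives a 1.7-fold lower number from compound 2 to compound 3 (0.23 log units; within the scatter). At this place, para to a large group, a group with no ring and with hydrogen-bond acceptors therefore reads the same as a group with a six-membered non-aromatic ring and no acceptors, despite their different sizes. Compound 2 and compound 3 both give true numbers, so this comparison is not cut off by the one ceiling seen so far: the limit of > 100000 nM in this assay, at which 1 of the 3 values shown sits.

From the compounds shown here alone, it remains open how a carboxylic acid or an amine on this aromatic carbon would read. Going by these compounds, it is also open whether an ester with a longer chain would stay as close to compound 2 as compound 3 does.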